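Swapping acetyl for bromo: the expected binding of compound 3

The source may hold more compounds than are shown below. What is called first, only, known or untested is meant among the compounds shown, and "the series" means these compounds.

Compound 1, `CCN(CC)c1cc(C)nc(N(CC)c2c(Br)cc(OC)cc2OC)n1`, gives 48 nM in an assay on isolated protein for binding affinity to corticotropin-releasing factor receptor 1 (Homo sapiens); a lower number here means a stronger inhibitor, a higher number a weaker inhibitor.
Compound 2, `CCN(CC)c1cc(C)nc(N(CC)c2c(Br)cc(C(C)=O)cc2OC)n1`, gives 28 nM in this assay.

Compound 2 shows the lowest of the two numbers, but since a 1.7-fold lower number from compound 1 to compound 2 (0.23 log units; within the scatter) lies within the scatter, the two compounds cannot be ranked. Compound 3, `CCN(CC)c1cc(C)nc(N(CC)c2c(Br)cc(Br)cc2OC)n1`, differs from compound 2 by bromo in place of acetyl on an aromatic carbon. For the measured compounds named here, no measured step exchanges acetyl for bromo; the one step at this position, a 1.7-fold lower number from compound 1 to compound 2 (0.23 log units; within the scatter), was small. The step of a 1.1-fold higher number from compound 2 to compound 3 (0.03 log units; within the scatter) is therefore expected to be small as well, with no clear direction beyond the scatter. Compound 3 is estimated at 30 nM in this assay, ranging from 10 nM to 90 nM.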

Compound 3, inhibition constant: 31 nM
The estimate for compound 3 lay 1.0-fold (0.01 log units) below the measured number; the range from low to high includes it.
By their numbers in this assay, from the lowest: compounds 2, 3 and 1 (each within the scatter of the next).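

At this position, para to a large group, the single heavy atom of bromo takes the place of the three heavy atoms of acetyl, and the hydrogen-bond acceptor of acetyl goes with them, yet this assay gives only a 1.1-fold higher number from compound 2 to compound 3 (0.04 log units; within the scatter). Bromo in place of methoxy also gives no readable change, with a 1.5-fold lower number from compound 1 to compound 3 (0.19 log units; within the scatter), so the three groups shown here cannot be told apart. Nothing measured here accounts for this. Going by these compounds, whether an amine or a carboxylic acid at this position would move the number beyond the scatter stays open, and so does the effect of a longer chain.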